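Taking the chloro group off compound 2

This account rests on a few compounds, and the source may have more. Where it says the series, first, only, none or still open, it means among the compounds named here.

In a functional assay, read by Griess assay, with a stated time of 2.5 h (on this read-out higher numbers stand for weaker inhibition and lower numbers for stronger inhibition), compound 1 `COc1cc(OC)c(OC)cc1/C=C/C(=O)c1ccc(Cl)cc1` gives 2.01 ug/mL and compound 2 `COc1cc(OC)c(OC)cc1/C=C/C(=O)c1ccc(Cl)c([N+](=O)[O-])c1` gives 1.99 ug/mL so the two stand level, within the scatter of repeated measurements. Compound 3 `COc1cc(OC)c(OC)cc1/C=C/C(=O)c1cccc([N+](=O)[O-])c1` keeps the nitro group of compound 2 but has hydrogen in place of chloro on an aromatic carbon, a change counted as hydrogen in place of chloro on an aromatic carbon and sitting ortho to a nitro group. Among the compounds with values here, no measured step removes a chloro group, so this swap has no direct precedent here. Within the data shown here, the nearest guide is the single step starting at compound 1 with nitro in place of hydrogen on an aromatic carbon, which shows a 1.0-fold lower number from compound 1 to compound 2 (0.00 log units; within the scatter) and stays within the scatter. On that thin evidence, the expected change is a 1.0-fold higher number from compound 2 to compound 3 (0.00 log units; within the scatter) in this assay and no shift beyond the scatter in either direction is anticipated. For compound 3 the estimated value is 2 ug/mL and the expected range runs from 0.9 ug/mL to 4.5 ug/mL in this read-out.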

Compound 3, half-maximal inhibitory concentration: 2.35 ug/mL
Compound 3: the middle estimate sits 1.2-fold (0.07 log units) below what was measured; measured number inside the range.
By their numbers in this assay, from the lowest: compounds 2, 1 and 3 (each within the scatter of the next).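

In this assay the step is a 1.2-fold higher number from compound 2 to compound 3 (0.07 log units; within the scatter), so compound 2 and compound 3 stand level and this position, ortho to a nitro group, accepts hydrogen as readily as chloro. The earlier step, a 1.0-fold lower number from compound 1 to compound 2 (0.00 log units; within the scatter), only added the nitro group, whereas this one shows that with the nitro group present the chloro group can go without moving the number beyond the usual scatter. Nothing measured here accounts for why the number holds.

All the compounds shown carry only chloro or hydrogen at this position, so it remains open whether an amine, a carboxylic acid or a longer chain there would shift the number in either direction. Going by these compounds, it also remains open whether swapping chloro for hydrogen reads the same on a ring without the nitro group.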